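Trichlorophenyl Replaces Chloromethylphenyl on the Triazole Nitrogen

A few compounds are considered here, and "the series" means these few. Any claim that something is new, unique, unknown or untested is made for them only; others in the source may bear on it.

Of the compounds shown here, three sharing one core have been tested in a functional assay on HepG2 cells (Homo sapiens) for antiproliferative activity, read by MTT assay, with a stated time of 48 h; a lower number here means a stronger inhibitor, a higher number a weaker inhibitor. Compound 1 `COc1ccc(-n2nncc2CN2C(=O)C3(C(C#N)=C(N)Oc4c(N)cc5nc6ccccc6nc5c43)c3ccccc32)cc1` carries a 4-methoxyphenyl group on an aromatic nitrogen; in this assay compound 1 gives > 50000 nM, which is a limit of the assay rather than a number. Compound 2 `CCOc1ccc(-n2nncc2CN2C(=O)C3(C(C#N)=C(N)Oc4c(N)cc5nc6ccccc6nc5c43)c3ccccc32)cc1` carries a 4-ethoxyphenyl group instead; in this assay compound 2 also gives > 50000 nM, again a limit. Compound 3 `Cc1ccc(Cl)cc1-n1nncc1CN1C(=O)C2(C(C#N)=C(N)Oc3c(N)cc4nc5ccccc5nc4c32)c2ccccc21` carries a 5-chloro-2-methylphenyl group on that nitrogen, and in this assay compound 3 gives 17300 nM. Going by the values given here, this is the only number among the three results, since the other two sit at the limit (the limit of > 50000 nM in this assay, at which 2 of the 3 values shown sit). The steps of an at least 2.8-fold lower number from compound 1 to compound 3 (0.46 log units; beyond the scatter) and an at least 2.8-fold lower number from compound 2 to compound 3 (0.46 log units; beyond the scatter) both show that the chloro-methyl-substituted phenyl ring gives a lower number than either alkoxyphenyl ring.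

Compound 4 `N#CC1=C(N)Oc2c(N)cc3nc4ccccc4nc3c2C12C(=O)N(Cc1cnnn1-c1c(Cl)cc(Cl)cc1Cl)c1ccccc12` differs from compound 3 in one place: 2,4,6-trichlorophenyl in place of 5-chloro-2-methylphenyl on an aromatic nitrogen. Both the group that leaves and the group that enters are halogen-bearing phenyl rings without oxygen, so the change is smaller in kind than the measured steps, which traded an alkoxyphenyl for a halogenated ring. The step of a 1.3-fold lower number from compound 3 to compound 4 (0.12 log units; within the scatter) is therefore expected to stay within the scatter. In this assay compound 4 is estimated at 13000 nM, with a likely range from 5000 nM to 40000 nM.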

Compound 4, half-maximal inhibitory concentration: 37800 nM
For compound 4 the middle estimate is 2.9-fold (0.46 log units) below the measured one, and the stated range covers the measured number.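

The aromatic nitrogen of the five-membered ring responds even to an exchange between two chlorine-bearing phenyl rings: in this assay this change gives a 2.2-fold higher number from compound 3 to compound 4 (0.34 log units; beyond the scatter) and so shows that chlorine on this ring does not by itself set the number. Going by these compounds alone, the earlier steps could be read as a general gain for a halogenated ring over an alkoxyphenyl ring, but compound 4 does not clearly support that reading, with an at least 1.3-fold lower number from compound 2 to compound 4 (0.12 log units; that floor lies within the scatter) and an at least 1.3-fold lower number from compound 1 to compound 4 (0.12 log units; that floor lies within the scatter) as the only comparisons. These two steps give only floors because the alkoxyphenyl compounds have limits rather than numbers: the limit of > 50000 nM in this assay, at which 2 of the 4 values shown sit.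

Compound 4 differs from compound 3 by both losing the methyl and gaining chlorines, so the compounds shown leave open which part of the change carries the step. They also leave open how a phenyl ring bearing an amine or a carboxylic acid would read at this position in this assay and whether any group here can take the number well beyond that of compound 3.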